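Swapping chloro for dimethyl on the benzoyl ring

This account rests on a few compounds, and the source may have more. Where it says the series, first, only, none or still open, it means among the compounds named here.

Compound 1 `Cc1cccc(C(=O)c2c(OCC(=O)Nc3ccc(S(N)(=O)=O)cc3C)ccc3cc(C#N)ccc23)c1` gives 15200 nM in an ADME assay on C8166 cells (Homo sapiens) for cytotoxicity, read by colorimetric assay and MTT assay; a lower number here means that less compound is tolerated, a higher number that more compound is tolerated.
Compound 2 `Cc1cc(S(N)(=O)=O)ccc1NC(=O)COc1ccc2cc(C#N)ccc2c1C(=O)c1cccc(Cl)c1` gives > 374000 nM in this assay; this is a limit of the assay, not a number.

Compound 2 therefore stands at the limit of > 374000 nM in this assay, at which 1 of the 2 values shown sits, with no number of its own. Compound 3 `Cc1cc(C)cc(C(=O)c2c(OCC(=O)Nc3ccc(S(N)(=O)=O)cc3C)ccc3cc(C#N)ccc23)c1` differs from compound 2 by 3,5-dimethylphenyl in place of 3-chlorophenyl on a carbonyl carbon. For the measured compounds named here, the only measured step, an at least 24-fold higher number from compound 1 to compound 2 (1.39 log units; beyond the scatter), went in the opposite direction, from methyl to chloro, and was large. Returning toward methyl, compound 3 is expected to fall back below the limit, estimated at 30000 nM with a range of 8000 nM to 374000 nM. That expectation corresponds to the step of an at least 12-fold lower number from compound 2 to compound 3 (1.09 log units; beyond the scatter).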

Compound 3, half-maximal cytotoxic concentration: 128000 nM
Compound 3: middle estimate off by 4.3-fold (0.63 log units), on the low side, within the range that was stated.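

Chlorine on the benzoyl ring is not needed for a high number in this assay: one more methyl in place of hydrogen on an aromatic carbon gives an 8.4-fold higher number from compound 1 to compound 3 (0.93 log units; beyond the scatter). Even so, replacing 3-chlorophenyl with 3,5-dimethylphenyl on the carbonyl carbon gives an at least 2.9-fold lower number from compound 2 to compound 3 (0.46 log units; beyond the scatter). Compound 2 gives > 374000 nM, which is a limit of the assay and not a number.

As far as these compounds go, the full size of that drop therefore stays open. So does the effect of a methoxy group, an amine or a carboxylic acid on this ring.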